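Swapping the amide aryl for a methylpyridinyl ring

The source may report more compounds than this note shows. Statements on the series, on what has been measured and on what is new or still open speak of the compounds shown alone.

Three compounds share one core and differ only in the ring on the amide nitrogen. Compound 1 `Cc1ccc(NC(=O)COc2ccc3cc(/C=C4/SC(=O)NC4=O)ccc3c2)cc1` gives 1700 nM in an assay on isolated protein for inhibition of histone deacetylase 4 (Homo sapiens), with a stated time of 1 h (on this read-out lower numbers stand for stronger inhibition and higher numbers for weaker inhibition), the lowest of the three numbers, although the gap to compound 2 `O=C(COc1ccc2cc(/C=C3/SC(=O)NC3=O)ccc2c1)Nc1ccc(Br)cc1F` (a 1.1-fold higher number from compound 1 to compound 2 (0.05 log units; within the scatter)) is within the scatter, so these two cannot be told apart; compound 2 gives 1900 nM. Compound 3 `COc1ccc(NC(=O)COc2ccc3cc(/C=C4/SC(=O)NC4=O)ccc3c2)cc1` gives 4700 nM, and both a 2.8-fold higher number from compound 1 to compound 3 (0.44 log units; beyond the scatter) and a 2.5-fold higher number from compound 2 to compound 3 (0.39 log units; beyond the scatter) are modest steps beyond the scatter.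

Compound 4 `Cc1cccc(NC(=O)COc2ccc3cc(/C=C4/SC(=O)NC4=O)ccc3c2)n1` is not yet measured. Its change from compound 1 is 6-methylpyridin-2-yl in place of 4-methylphenyl on an amide-type nitrogen. Among the compounds with values here, all three known steps also vary the ring on the amide nitrogen, and they range from within the scatter to modest, so a step of at most modest size in this assay is expected here too, with no clear direction and a slight lean toward a higher number, since no measured compound carries a ring nitrogen at this place.

Compound 4 is therefore expected to give about 2500 nM in this assay, between 1000 nM and 6500 nM. The estimated step of a 1.5-fold higher number from compound 1 to compound 4 (0.17 log units; within the scatter) is expected to stay close to the scatter.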

Compound 4, half-maximal inhibitory concentration: 1100 nM
The estimate for compound 4 lay 2.3-fold (0.36 log units) above the measured number; the measured number falls inside the stated range.
By their numbers in this assay, from the lowest: compounds 4, 1 and 2 (each within the scatter of the next); then compound 3.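

Swapping 4-methylphenyl for 6-methylpyridin-2-yl puts a ring nitrogen and a hydrogen-bond acceptor at this place with no loss in this assay (a 1.5-fold lower number from compound 1 to compound 4 (0.19 log units; within the scatter); a 1.7-fold lower number from compound 2 to compound 4 (0.24 log units; within the scatter)), so compound 4 cannot be told apart from compound 1 or compound 2. Within the data shown here, measured against the methoxy-bearing ring, the same pyridinyl ring gives the largest step at this place so far (a 4.3-fold lower number from compound 3 to compound 4 (0.63 log units; beyond the scatter)), although that step is still modest. Nothing available explains why the ring nitrogen is accepted here.

What the ring nitrogen does on its own remains open, as the compounds shown include no pyridin-2-yl ring without its methyl group. They also leave open how this place responds to a ring carrying an amine or a carboxylic acid.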